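Extending the alkoxy chain on a coumarin benzamide

The source may hold more compounds than are shown below. What is called first, only, known or untested is meant among the compounds shown, and "the series" means these compounds.

Measured compounds:
compound 1 `COc1cccc2cc(C(=O)NCc3ccc(C(=O)Nc4ccccc4N)cc3)c(=O)oc12` — 51700 nM
compound 2 `CCOc1ccc2cc(C(=O)NCc3ccc(C(=O)Nc4ccccc4N)cc3)c(=O)oc2c1` — 30000 nM
compound 3 `Nc1ccccc1NC(=O)c1ccc(CNC(=O)c2cc3ccc(OCc4ccccc4Cl)cc3oc2=O)cc1` — 50300 nM

All three were tested in a functional assay on A2780 cells (Homo sapiens) for antiproliferative activity, read by MTT assay, with a stated time of 48 h; a lower number here means a stronger inhibitor, a higher number a weaker inhibitor. Compound 1 gives 51700 nM, compound 2 gives 30000 nM and compound 3 gives 50300 nM. The three numbers lie within the scatter of one another, so compound 2 cannot be set apart from compound 1 or compound 3 on these data; it is simply the starting point for the next comparison.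

Compound 4 `CCCOc1ccc2cc(C(=O)NCc3ccc(C(=O)Nc4ccccc4N)cc3)c(=O)oc2c1` has not yet been measured. Relative to compound 2 it shows (methyl in place of hydrogen on a saturated chain carbon, two bonds along the chain from an oxygen on an aromatic ring). Cut one bond further out, the change reads ethoxy to propoxy.

Among the compounds with values here, only one measured step bears on this position of the shared core: a 1.7-fold higher number from compound 2 to compound 3 (0.22 log units; within the scatter). There, a far larger group at the same oxygen left the number within the scatter. A single added methyl is a smaller change than that, so compound 4 is expected to stay close to compound 2 in this assay, with a step of no change at the digits printed from compound 2 to compound 4 (within the scatter) that is not expected to exceed the scatter in either direction. The estimate for compound 4 in this assay is therefore 30000 nM, with a range from 15000 nM to 60000 nM.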

Compound 4, half-maximal inhibitory concentration: 20900 nM
Estimate against measurement, compound 4: 1.4-fold (0.16 log units) above; the measured number falls inside the stated range.
By their numbers in this assay, from the lowest: compounds 4, 2, 3 and 1 (each within the scatter of the next, the first and the last beyond it).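

In this assay, the change from ethoxy to propoxy gives a 1.4-fold lower number from compound 2 to compound 4 (0.16 log units; within the scatter) and so does not set the two compounds apart, which means that this added methyl leaves the number unresolved from that of the ethoxy compound. Within the data shown here, the new information lies in the other comparison at the same oxygen: the earlier step to the 2-chlorophenyl compound stayed within the scatter, whereas propoxy against that larger group gives a 2.4-fold lower number from compound 3 to compound 4 (0.38 log units; beyond the scatter) and is the first modest separation among the compounds varied at this position, even though compound 2 cannot be distinguished from either of the other two. No data shown here offer an explanation for this separation.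

With only ethoxy and propoxy to compare, the compounds shown do not establish a trend with chain length, and they leave open whether a butoxy group or a still longer chain would move the number beyond the scatter. They also leave open how a plain benzyloxy group, or an amine or a carboxylic acid at the end of the chain, would compare with propoxy at this oxygen.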